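Swapping the Chlorine and Trifluoromethyl Pattern on a Urea

The source may report more compounds than this note shows. Statements on the series, on what has been measured and on what is new or still open speak of the compounds shown alone.

Of the compounds shown here, two have so far been measured in a functional assay on MX1 cells (Homo sapiens) for inhibition, read by MTT assay, with a stated time of 120 h; on this read-out lower numbers stand for stronger inhibition and higher numbers for weaker inhibition. For the measured compounds named here, compound 1, with the structure `CC(NC(=O)C#Cc1ccc(NC(=O)Nc2cc(C(F)(F)F)ccc2Cl)cc1)c1ccccc1`, is the only one with an actual number: in this assay compound 1 gives 16100 nM, and it therefore serves as the reference point here. Compound 2, with the structure `CC1CN(C(=O)c2ccc(-c3ccc(NC(=O)Nc4ccc(Cl)c(C(F)(F)F)c4)cc3)cc2)CC(C)O1`, is a different case. In this assay compound 2 reaches only > 50000 nM, which is a limit of the assay and not a number; it sits at the limit of > 50000 nM in this assay, at which 1 of the 2 values shown sits.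

Compound 3, with the structure `CC(NC(=O)C#Cc1ccc(NC(=O)Nc2ccc(Cl)c(C(F)(F)F)c2)cc1)c1ccccc1`, has not yet been measured. It keeps every atom of compound 1 but joins them differently: 4-chloro-3-(trifluoromethyl)phenyl in place of 2-chloro-5-(trifluoromethyl)phenyl on an amide-type nitrogen. Going by the values given here, no pair of measured compounds that differ in just one place is available, and the two measured compounds differ at several places, so the data offer no direct guide to the size of this step. The step expected in this assay is a 1.6-fold lower number from compound 1 to compound 3 (0.21 log units; within the scatter), a change of modest size that may well stay within the usual scatter. For compound 3 the estimate in this assay is 10000 nM, with a range from 3000 nM to 50000 nM.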

Compound 3, half-maximal inhibitory concentration: 12800 nM
The estimate for compound 3 lay 1.3-fold (0.11 log units) below the measured number; the measured number falls inside the stated range.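

For the compounds shown here, this is the first pair of compounds that differ in just one place, so the effect of a change in the group on an amide-type nitrogen can now be read directly instead of guessed. In this assay, putting 4-chloro-3-(trifluoromethyl)phenyl in place of 2-chloro-5-(trifluoromethyl)phenyl gives a 1.3-fold lower number from compound 1 to compound 3 (0.10 log units; within the scatter), so rearranging these same atoms leaves the two compounds indistinguishable on this read-out, and this particular rearrangement can be set aside as a way of changing the number. Nothing shown here offers an explanation for this result.

From the compounds shown here alone, it remains open whether a truly different group at this place, such as a phenyl ring carrying an amine, a carboxylic acid or a methoxy group in place of the chlorine, would shift the number beyond the usual scatter. It is also unknown whether the same rearrangement would behave alike on another core, since compound 2 differs from compound 3 at several places and so cannot answer that question.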